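A few compounds are considered here, and "the series" means these few. Any claim that something is new, unique, unknown or untested is made for them only; others in the source may bear on it.

Measured so far in a physicochemical assay for lipophilicity, at pH 7.4; a higher number here means a more lipophilic compound, a lower number a more polar compound:
compound 1 `COc1ccccc1-c1ccc(-c2nnc(N(C)Cc3ccc4nccn4c3)o2)cc1` gives 4.1
compound 2 `Cc1ccccc1-c1ccc(-c2nnc(N(C)Cc3ccc4nccn4c3)o2)cc1` gives 4.7
compound 3 `COc1cc(-c2c(C)nn(C)c2C)ccc1-c1nnc(N(C)Cc2ccc3nccn3c2)o1` gives 2.9

Compound 4 `Cc1cc(-c2c(C)nn(C)c2C)ccc1-c1nnc(N(C)Cc2ccc3nccn3c2)o1` remains to be measured. Within the data shown here, the one measured step, (methyl in place of methoxy on an aromatic carbon), reads a number 0.60 log units higher from compound 1 to compound 2 (beyond the scatter). The same kind of change carries compound 3 to compound 4, (methyl in place of methoxy on an aromatic carbon); around the place it differs in that the carbon is also meta to a 1,3,5-trimethyl-1H-pyrazol-4-yl group, whereas in compound 1 it is only ortho to a large group. The difference between the core of compound 1 and the core of compound 3 is not broken down here; compound 3 stands lowest of the three in this assay, with compound 1 nearest. Among the measured compounds shown here, a step of a number 0.60 log units higher from compound 3 to compound 4 (beyond the scatter) is expected for compound 4 because a number 0.60 log units higher from compound 1 to compound 2 (beyond the scatter) is the only measured precedent. Compound 4 is estimated at 3.5, between 3.1 and 3.9.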

Compound 4, distribution coefficient: 3.7
Compound 4: the middle estimate sits 0.20 log units below what was measured, and the stated range covers the measured number.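

In this assay, methyl in place of methoxy on an aromatic carbon gives a number 0.80 log units higher from compound 3 to compound 4 (beyond the scatter) and, on the other core, a number 0.60 log units higher from compound 1 to compound 2 (beyond the scatter); both steps lie beyond the scatter and point the same way, so the direction of the change carried from one core to the other. This rests on one pair per core and shows a shared direction for these four compounds, not a rule for the series. Nothing measured here bears on why the step occurs or what sets its size on either core.

Open, going by these compounds, is whether the direction holds on any core beyond these two. Also open, on these data alone, is what a group other than methyl or methoxy at this place, such as chlorine, a nitrile or a primary amine, would give in this assay.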